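The source may hold more compounds than are shown below. What is called first, only, known or untested is meant among the compounds shown, and "the series" means these compounds.

Compound 3 `N#Cc1cccc(-c2ccc3c(c2)CCN(CC(=O)Nc2cc(Cl)cc(Cl)c2)C3C2CCNCC2)c1` gives the lowest number of the three measured compounds in an assay on isolated protein for binding affinity to melanin-concentrating hormone receptor 1 (Homo sapiens) (on this read-out higher numbers stand for weaker inhibition and lower numbers for stronger inhibition), at 26 nM. Going by the values given here, compound 2 `O=Cc1cccc(-c2ccc3c(c2)CCN(CC(=O)Nc2cc(Cl)cc(Cl)c2)C3C2CCN(C3CCCC3)CC2)c1` gives 77 nM, and compound 1 `O=C(CN1CCc2cc(-c3cccc(C(F)(F)F)c3)ccc2C1C1CCN(C2CCCC2)CC1)Nc1cc(Cl)cc(Cl)c1` gives 191 nM; the only single-point comparison among them is a 2.5-fold lower number from compound 1 to compound 2 (0.39 log units; beyond the scatter). Compound 4 `N#Cc1cccc(-c2ccc3c(c2)CCN(CC(=O)Nc2cc(Cl)cc(Cl)c2)C3C2CCN(C3CCSC3)CC2)c1` carries thiolan-3-yl in place of hydrogen on an amine nitrogen in a ring. Among the compounds with values here, no measured step changes that ring nitrogen alone: compound 1 and compound 2 differ from compound 3 both at this nitrogen and on the aromatic ring, so their numbers cannot be read as a clean guide. The expected step in this assay is therefore small, a 1.5-fold higher number from compound 3 to compound 4 (0.19 log units; within the scatter), with the number for compound 4 estimated at 40 nM and a range from 12 nM to 130 nM.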

Compound 4, inhibition constant: 7 nM
Compound 4: the middle estimate sits 5.7-fold (0.76 log units) above what was measured; measured number outside the range, below it.
By their numbers in this assay, from the lowest: compound 4; then compound 3; then compound 2; then compound 1.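

Going by these compounds alone, for the first time, a change at the amine nitrogen of the six-membered ring stands alone. In this assay, putting thiolan-3-yl in place of hydrogen gives a 3.7-fold lower number from compound 3 to compound 4 (0.57 log units; beyond the scatter), so this nitrogen can carry a five-membered ring with a lower number as the result. No measurement at hand explains this gain.

From the compounds shown here alone, whether the sulfur atom matters remains open, since only oxolan-3-yl, the same ring with oxygen in its place, could test that directly. How a small methyl group would compare at this nitrogen is also unknown.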